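Pyrrole to methylfuran swap on the arylidene cyanoacrylamide series

The source may hold more compounds than are shown below. What is called first, only, known or untested is meant among the compounds shown, and "the series" means these compounds.

Measured so far:
- compound 1 `N#C/C(=C\c1c(F)c(F)c(F)c(F)c1F)C(=O)c1ccc[nH]1`: > 100000 nM
- compound 2 `COc1ccc(CNC(=O)/C(C#N)=C/c2ccc[nH]2)cc1`: > 50000 nM
- compound 3 `N#C/C(=C\c1ccco1)C(=O)NCc1ccc(Cl)c(Cl)c1`: 38000 nM

The read-out throughout is a functional assay on SMA cells (Homo sapiens) for inhibition, read by MTT assay, with a stated time of 72 h; a higher number here means a weaker inhibitor of growth, a lower number a stronger inhibitor of growth. For compound 1 the entry > 100000 nM is a limit of the assay, not a number (the limit of > 100000 nM in this assay, at which 1 of the 3 values shown sits). For compound 2 the entry > 50000 nM is likewise only a limit (the limit of > 50000 nM in this assay, at which 1 of the 3 values shown sits), so compound 2 stands at the edge of what this assay resolves, with no measured number of its own. Going by the values given here, compound 3, carrying a furan and a dichlorobenzyl amide, gives 38000 nM, the only actual number in the set; no single-point step connects compound 3 to the other two, so the three values are merely placed side by side.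

Compound 4 `COc1ccc(CNC(=O)/C(C#N)=C/c2ccc(C)o2)cc1` differs from compound 2 in one place: 5-methylfuran-2-yl in place of 1H-pyrrol-2-yl on a double-bonded chain carbon bound to a double-bonded chain carbon. Among the compounds with values here, no measured pair matches this change. Going on compound 2 at > 50000 nM and compound 3 at 38000 nM, compound 4 is expected to remain a weak inhibitor of growth, with a step in this assay from compound 2 to compound 4 of about a number no higher from compound 2 to compound 4 (the limit leaves the size open). It would not be surprising if the measurement of compound 4 came back as an edge value of the assay rather than as a number. The estimate for compound 4 is 50000 nM, within 15000 nM to 150000 nM.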

Compound 4, concentration for 50% growth inhibition: 69000 nM
Beside the measured number, compound 4's estimate is 1.4-fold (0.14 log units) below it, and the stated range covers the measured number.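

No step can be read from compound 2 to compound 4, because the entry for compound 2 is a limit and not a number: the limit of > 50000 nM in this assay, at which 1 of the 4 values shown sits.

The compounds shown leave open whether 5-methylfuran-2-yl in place of 1H-pyrrol-2-yl strengthens or weakens growth inhibition, and by how much.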